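The source may report more compounds than this note shows. Statements on the series, on what has been measured and on what is new or still open speak of the compounds shown alone.

Measured compounds:
- compound 1 `COc1cc2cc(Oc3ccc(NC(=O)Nc4ccc(C)cc4)cc3)c(C)nc2cc1OC`: 101%
- compound 2 `COc1cc2cc(Oc3ccc(NC(=O)Nc4cccc(C(F)(F)F)c4)cc3)c(C)nc2cc1OC`: 8.77%

Both compounds were tested in a functional assay on IGROV-1 cells (Homo sapiens) for inhibition, read by sulforhodamine B assay, with a stated time of 48 h, tested at 10 uM; on this read-out lower numbers stand for a stronger effect and higher numbers for a weaker effect at the one concentration tested. Compound 2 stands at the lower of the two numbers, the stronger effect; its nearest neighbour is compound 1, and the step of a number 92.2 percentage points lower from compound 1 to compound 2 (beyond the scatter) separates the two, a change that lies well beyond the usual scatter of repeated measurements.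

Compound 3 `COc1cc2cc(Oc3ccc(NC(=O)Nc4ccc(Cl)c(Cl)c4)cc3)c(C)nc2cc1OC` has not yet been measured. It differs from compound 2 only in one place: 3,4-dichlorophenyl in place of 3-(trifluoromethyl)phenyl on an amide-type nitrogen.

Among the compounds with values here, the only measured step, from compound 1 to compound 2, also concerns the aryl group carried on the amide-type nitrogen, and it was large. Within the data shown here, it shows that this part of the molecule can swing the read-out across almost its whole range, but it does not say how a 3,4-dichlorophenyl compares with a 3-(trifluoromethyl)phenyl; no measured pair covers that exchange. The expectation therefore rests on compound 2 alone, with a wide allowance. Compound 3 is expected to remain near compound 2, with a step of a number 11.2 percentage points higher from compound 2 to compound 3 (beyond the scatter) anticipated, giving an estimated 20% within a range from 3% to 55%.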

Compound 3, a percentage reported as activity, at one concentration (the size of the read-out at that concentration, not a potency): 18.6%
Compound 3: the middle estimate sits 1.4 percentage points above what was measured; the measured number falls inside the stated range.
By their numbers in this assay, from the lowest: compounds 2 and 3 (each within the scatter of the next); then compound 1.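

In this assay, placing 3,4-dichlorophenyl on the amide-type nitrogen instead of 3-(trifluoromethyl)phenyl gives a number 9.8 percentage points higher from compound 2 to compound 3 (within the scatter), so this read-out does not separate the two groups. Against the 4-methylphenyl group, the same 3,4-dichlorophenyl group gives a number 82.4 percentage points lower from compound 1 to compound 3 (beyond the scatter), which shows that the large change seen earlier is not confined to 3-(trifluoromethyl)phenyl: a second aryl group with different substituents also gives it. Nothing available here offers a measured explanation of why these two groups read alike or why 4-methylphenyl stands so far from both.

The compounds shown leave open how a plain phenyl group, a phenyl group with one chlorine, or a phenyl group carrying a nitrile, an amine or a carboxylic acid would read at this position, so it remains unknown what on the ring accounts for the gap to compound 1. Since each number comes from one concentration, they also leave open whether compound 2 and compound 3 would still read alike across a range of concentrations.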